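A Small Swap at the Edge of a Sulfonamide

The source may report more compounds than this note shows. Statements on the series, on what has been measured and on what is new or still open speak of the compounds shown alone.

Within the data shown here, compound 1, with the structure `COc1cc(N)c(Cl)cc1C(=O)CCC1CCN(CCNS(=O)(=O)c2ccc(N)cc2)CC1`, is the only member of this small set with a numerical read-out: in an assay on HEK293 cells for displacement of a labelled ligand from 5-hydroxytryptamine receptor 6 (Homo sapiens), with a stated time of 60 min, tested at 0.01 uM, in the presence of a further agent that is not named here (a higher number here means a stronger effect of the compound at the concentration tested, a lower number a weaker effect), compound 1 gives 7%. A related compound 2, built as `COc1ccc(S(=O)(=O)N2CCC(CCC(=O)c3cc(Cl)c(N)cc3OC)CC2)cc1`, is reported in this assay only as "not active" (no number reported), without a number. So compound 1 stands alone on the numbers shown, and the single value it has is a weak one.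

Compound 3, drawn as `COc1cc(N)c(Cl)cc1C(=O)CCC1CCN(CCNS(=O)(=O)c2ccc(C)cc2)CC1`, departs from compound 1 by one change: methyl in place of amino on an aromatic carbon. Among the measured compounds shown here, no measured pair in this set shows that same change, so nothing here tells how big its effect is. For the measured compounds named here, the weak starting point of compound 1 leaves little room for a fall, and no measured step supports a rise.

The expectation is a step of a number 2 percentage points lower from compound 1 to compound 3 (within the scatter) in this assay, that is, none beyond the usual scatter. Compound 3 is therefore estimated at 5%, with a range from -5% to 15%.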

Compound 3, a percentage reported as inhibition, at one concentration (the size of the read-out at that concentration, not a potency): "not active" (no number reported)
Compound 3: no number reported; the estimate stays without a comparison.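

Among these compounds, compound 3 is reported in this assay as "not active" without a number, so no step from compound 1 to compound 3 can be read. No evidence here bears on this result. The compounds shown leave open whether methyl in place of amino changes the read-out at all.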